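The compounds below may be only part of what the source reports. "The series", "measured", "known", "first", "only" and "open" are said of these compounds alone.

Working notes on the series, with all readings taken from a functional assay on HCT-116 cells (Homo sapiens) for inhibition (on this read-out lower numbers stand for stronger inhibition and higher numbers for weaker inhibition), so far. Compound 1 (`CCNC(=O)c1noc(-c2cc(C(C)C)c(O)cc2O)c1-c1cc(COCC(=O)O)no1`) stands as "not determined" (no result reported) in this assay and offers no comparison. Compound 2 (`CCNC(=O)c1noc(-c2cc(C(C)C)c(O)cc2O)c1-c1cc(CN(C)C)no1`) gives 92 nM and is the only numerical reference, with no other value to rank it against. Compound 3 (`CCCN(CCC)Cc1cc(-c2c(C(=O)NCC)noc2-c2cc(C(C)C)c(O)cc2O)on1`) is still unmeasured and shares the core of compound 2. The structural change is dipropylamino in place of dimethylamino on a saturated chain carbon bound to an aromatic carbon and it leaves the saturated chain carbon bound to an aromatic carbon in place. Within the data shown here, no measured pair shows the size of a change at this group, so any expectation remains loose. The expected step is a 1.3-fold higher number from compound 2 to compound 3 (0.12 log units; within the scatter) and it is estimated to stay near the usual scatter, if anything towards weaker inhibition. In this assay the expected value for compound 3 is 120 nM within an estimated range of 40 nM to 350 nM for now.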

Compound 3, half-maximal inhibitory concentration: 183 nM
For compound 3 the middle estimate is 1.5-fold (0.18 log units) below the measured one, and the stated range covers the measured number.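

In this assay, among these compounds, this is the first measured pair at this position: on a saturated chain carbon bound to an aromatic carbon, dipropylamino in place of dimethylamino gives a 2.0-fold higher number from compound 2 to compound 3 (0.30 log units; within the scatter) and the core stays the same. The position therefore carries a group of 7 heavy atoms in place of one of 3 with readings that stay within the scatter of each other, so these two amines are not separated by this read-out. Nothing available here bears on the reason for this result.

On these data alone, a ring amine such as piperidine or morpholine, a primary amine, and a chain longer than propyl on the nitrogen remain open at this place. Compound 1, which carries a carboxylic acid on its side chain, stands at "not determined" (no result reported), so an acid at this position offers no comparison with either amine.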